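The source may report more compounds than this note shows. Statements on the series, on what has been measured and on what is new or still open speak of the compounds shown alone.

Measured so far in an in vitro ADME assay on microsomes from liver (Homo sapiens) for metabolic stability; on this read-out higher numbers stand for fast clearance and lower numbers for slow clearance: compound 1 `O=C(COCc1ccccc1)N1CCN(c2ccc(Cl)cc2)CC1` gives 290 mL.min-1.g-1; compound 2 `O=C(COCc1ccccc1)N1CCN(c2ccc(Cl)cc2Cl)CC1` gives 450 mL.min-1.g-1; compound 3 `O=C(COCc1ccccc1)N1CCN(c2ccc(F)cc2Cl)CC1` gives 530 mL.min-1.g-1.

Among these three numbers compound 2 holds the second highest place, though all three lie close together. Its nearest neighbour is compound 3, separated by a 1.2-fold higher number from compound 2 to compound 3 (0.07 log units; within the scatter), and its furthest is compound 1, from which compound 2 is separated by a 1.6-fold higher number from compound 1 to compound 2 (0.19 log units; within the scatter); the remaining step, a 1.8-fold higher number from compound 1 to compound 3 (0.26 log units; within the scatter), is also within the scatter. In this assay the measured compounds therefore cannot be told apart with confidence.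

Compound 4 `O=C(COCc1cccnc1)N1CCN(c2ccc(Cl)cc2Cl)CC1` differs from compound 2 in one place: pyridin-3-yl in place of phenyl on a saturated chain carbon bound to an oxygen on a saturated carbon. Every measured step concerns the group on the amine nitrogen in a ring, so none of them bears on a change at the saturated chain carbon bound to an oxygen on a saturated carbon. Among the measured compounds shown here, no measured step sets a direction or a size for this change; what the three compounds do show is that each single-group swap has so far stayed within the scatter. The expected step is therefore a 1.5-fold lower number from compound 2 to compound 4 (0.18 log units; within the scatter), a move that is not expected to go beyond the scatter. Compound 4 is estimated at 300 mL.min-1.g-1, with a range from 140 mL.min-1.g-1 to 650 mL.min-1.g-1.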

Compound 4, intrinsic clearance in microsomes: 210 mL.min-1.g-1
Estimate against measurement, compound 4: 1.4-fold (0.15 log units) above; the measured number falls inside the stated range.
By their numbers in this assay, from the lowest: compounds 4, 1, 2 and 3 (each within the scatter of the next, the first and the last beyond it).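

Every earlier step concerned the group on the amine nitrogen in a ring, and none of those steps went beyond the scatter. In this assay, the change from phenyl to pyridin-3-yl on the saturated chain carbon bound to an oxygen on a saturated carbon gives a 2.1-fold lower number from compound 2 to compound 4 (0.33 log units; beyond the scatter) and is the first listed step to go beyond the scatter, though only modestly. This position can therefore move the read-out towards slow clearance with a single swap that keeps the heavy-atom count at the same value but exchanges one ring carbon for a nitrogen and adds a hydrogen-bond acceptor, and nothing available explains why the number moved.

The compounds shown leave open whether the location of the ring nitrogen matters, as pyridin-2-yl and pyridin-4-yl would show, and whether a non-aromatic group such as piperidin-4-yl or a simple methyl at this place would give a similar number. Going by these compounds, the step also rests on one pair, so it remains open whether pyridin-3-yl would give a similar step alongside the 4-chlorophenyl group of compound 1.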